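The source may hold more compounds than are shown below. What is called first, only, known or untested is meant among the compounds shown, and "the series" means these compounds.

Compound 1 `CCN(c1ccc(C#N)c(Cl)c1)c1cc(-c2ccccc2)ccc1C`: "not determined" (no result reported)
Compound 2 `CCN(c1cccc(-n2ccnc2)c1)c1ccc(C#N)c(C(F)(F)F)c1`: > 30000 nM
Compound 3 `CCN(c1ccc(C#N)c(Cl)c1)c1cc(-c2c[nH]nc2C)ccc1C`: 9030 nM

These results come from a functional assay on PC-3 cells (Homo sapiens) for antiproliferative activity, read by CCK-8 assay, with a stated time of 6 days; a higher number here means a weaker inhibitor, a lower number a stronger inhibitor. Compound 1 has no reported result, so it offers no comparison. Compound 2 gives only a limit, > 30000 nM, and not a number. That entry is the only one of its kind in the set: the limit of > 30000 nM in this assay, at which 1 of the 3 values shown sits. Compound 3 is the only one of the three with a number, 9030 nM.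

Compound 4 `CCN(c1ccc(C#N)c(C(F)(F)F)c1)c1cc(-n2ccnc2)ccc1C` departs from compound 2 by a single change, methyl in place of hydrogen on an aromatic carbon. Among the measured compounds shown here, no measured pair isolates this change, so its size in this assay remains an open question. A modest shift towards stronger inhibition is expected, though compound 4 may again return only a limit. The expected step is an at least 2.0-fold lower number from compound 2 to compound 4 (0.30 log units; that floor lies within the scatter). For compound 4 the estimated value is 15000 nM, with an expected range of 5000 nM to 30000 nM.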

Compound 4, half-maximal inhibitory concentration: > 30000 nM
Compound 4 ended at the assay's limit (the forecaster's own chance of this, stated with the estimate: 45%); at least 2.0-fold (0.30 log units) between middle value and limit.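

Compound 4, like compound 2, returns only a limit and not a number, so no step can be read between the two: the limit of > 30000 nM in this assay, at which 2 of the 4 values shown sit. The compounds shown leave open what methyl in place of hydrogen on an aromatic carbon changes in this assay.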